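Swapping piperidin-1-yl for diisopropylamino on a shared core

The source may report more compounds than this note shows. Statements on the series, on what has been measured and on what is new or still open speak of the compounds shown alone.

- compound 1 `OC[C@H]1O[C@@H](n2cnc3c(Cn4ccc5ccccc54)ncnc32)[C@H](O)[C@@H]1O` gives 5700 nM
- compound 2 `CSCc1ncnc2c1ncn2[C@@H]1O[C@H](CO)[C@@H](O)[C@H]1O` gives 13400 nM
- compound 3 `OC[C@H]1O[C@@H](n2cnc3c(CN4CCCCC4)ncnc32)[C@H](O)[C@@H]1O` gives 6900 nM

These numbers all come from a functional assay on HL-60 cells (Homo sapiens) for inhibition, with a stated time of 72 h (a lower number here means a stronger inhibitor, a higher number a weaker inhibitor), and differ only in the group on a saturated chain carbon bound to an aromatic carbon. At 6900 nM compound 3 lies within the scatter of both other compounds, so it cannot be ranked against either of them.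

The next compound is compound 4 `CC(C)N(Cc1ncnc2c1ncn2[C@@H]1O[C@H](CO)[C@@H](O)[C@H]1O)C(C)C`, which has diisopropylamino in place of piperidin-1-yl on that same carbon (diisopropylamino in place of piperidin-1-yl on a saturated chain carbon bound to an aromatic carbon). The entering group has no ring, while the leaving group has one.

Within the data shown here, no measured step makes this exact change, so the nearest guide is how much the group at this place has mattered so far. The comparison a 1.2-fold higher number from compound 1 to compound 3 (0.08 log units; within the scatter) is small, and so is a 1.9-fold lower number from compound 2 to compound 3 (0.29 log units; within the scatter) as well. The largest, a 2.4-fold higher number from compound 1 to compound 2 (0.37 log units; beyond the scatter), is still modest. Across these three quite different groups, the numbers stay close together.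

For this reason, no step beyond the scatter is expected in this assay here. The expected step is a 1.2-fold higher number from compound 3 to compound 4 (0.06 log units; within the scatter) and it is only an estimate. For compound 4 the estimated value is 8000 nM, with an expected range from 3500 nM to 18000 nM.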

Compound 4, half-maximal inhibitory concentration: 13000 nM
The estimate for compound 4 lay 1.6-fold (0.21 log units) below the measured number; the range from low to high includes it.
By their numbers in this assay, from the lowest: compounds 1, 3, 4 and 2 (each within the scatter of the next, the first and the last beyond it).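

In this assay, diisopropylamino, which has no ring, cannot be told apart from piperidin-1-yl on this saturated chain carbon, with a 1.9-fold higher number from compound 3 to compound 4 (0.28 log units; within the scatter) as the step, so the ring of the leaving group shows no clear effect here. Compound 4 also cannot be told apart from the methylsulfanyl compound, as a 1.0-fold lower number from compound 2 to compound 4 (0.01 log units; within the scatter) shows, yet a 2.3-fold higher number from compound 1 to compound 4 (0.36 log units; beyond the scatter) is a modest step beyond the scatter, which makes it the second such step at this carbon, alongside a 2.4-fold higher number from compound 1 to compound 2 (0.37 log units; beyond the scatter) and likewise starting from the 1H-indol-1-yl compound, although compound 3 goes against any rule that leaving 1H-indol-1-yl matters, with a 1.2-fold higher number from compound 1 to compound 3 (0.08 log units; within the scatter) staying within the scatter. No supporting data are available to explain these small differences.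

The compounds shown leave open whether a quite different group on this carbon, such as a carboxylic acid or a primary amine, could move the number well outside this narrow band. They also leave open whether a longer chain carrying the piperidin-1-yl ring would stay within that band.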